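Swapping Methoxy for Methyl on a Receptor Modulator

This account rests on a few compounds, and the source may have more. Where it says the series, first, only, none or still open, it means among the compounds named here.

Of the compounds shown here, three have so far been measured in an assay for positive allosteric modulation of metabotropic glutamate receptor 2 (Rattus norvegicus); on this read-out lower numbers stand for an effect already at smaller amounts and higher numbers for an effect only at larger amounts of compound. Compound 1 `Cc1ccc(OCCCCOc2ccc(C(=O)CC(C)(C)C)c(O)c2C)cc1C(=O)O` gives 210 nM in this assay. Compound 2 `COc1ccc(OCCCCOc2ccc(C(=O)CC(C)(C)C)c(O)c2C)cc1C(=O)O` gives 13 nM. Compound 3 `COc1cc(C(=O)O)ccc1OC[C@H](C)COc1ccc(C(=O)CC(C)(C)C)c(O)c1C` gives 28 nM. A fourth compound, compound 4 `Cc1cc(C(=O)O)ccc1OC[C@H](C)COc1ccc(C(=O)CC(C)(C)C)c(O)c1C`, still awaits measurement in this assay.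

Compound 2 and compound 1 differ in a single place: methyl in place of methoxy on an aromatic carbon. This change produced a 16-fold higher number from compound 2 to compound 1 (1.21 log units; beyond the scatter), a clear worsening.

Compound 3 and compound 2 are built from the same atoms joined differently; the difference between the two cores is not broken down here. Compound 3 stands closer to compound 2 than to compound 1 on this read-out.

Compound 4 differs from compound 3 by methyl in place of methoxy on an aromatic carbon. Among the measured compounds shown here, the change is of the same kind as the one from compound 2 to compound 1, but not the same: in compound 2 the methoxy sits ortho to a carboxy group and para to a large group, whereas in compound 3 it sits ortho to a large group and meta to a carboxy group.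

Because the same kind of change gave a 16-fold higher number from compound 2 to compound 1 (1.21 log units; beyond the scatter), a rise in the number is expected here as well, though the different surroundings make its size uncertain, so the step from compound 3 to compound 4 is estimated at a 5.0-fold higher number from compound 3 to compound 4 (0.70 log units; beyond the scatter). Compound 4 is accordingly expected to give about 140 nM, most likely between 40 nM and 600 nM.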

Compound 4, half-maximal effective concentration: 446 nM
Beside the measured number, compound 4's estimate is 3.2-fold (0.50 log units) below it; low and high end bracket the measured number.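

Across the two pairs, methyl in place of methoxy on an aromatic carbon has so far come with a clear loss in this assay, and the new pair gives a 16-fold higher number from compound 3 to compound 4 (1.20 log units; beyond the scatter). This does not show why the numbers rise, and two pairs are too few to predict the step on a further core, so the match applies only to compounds 1 to 4. What it does show is that the size of the step carried over from one core to the other, even though the group sits in different surroundings on each: the same change on two cores in this assay, a 16-fold higher number (1.21 log units; beyond the scatter) from compound 2 to compound 1 and a 16-fold higher number (1.20 log units; beyond the scatter) from compound 3 to compound 4, 1.0-fold (0.01 log units) apart, within the scatter of two such steps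

The compounds shown compare only methoxy and methyl at these places, so it remains open how an ethoxy group, a chlorine atom or a nitrile would fare there, and whether the number follows any simple trend across such groups. Going by these compounds, it also remains open whether the same step would appear with a longer chain linking the two aromatic rings, or with an amide in place of the carboxylic acid.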